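A Third Methoxy on a Styryl Lactone: Expected Growth Inhibition

A few compounds are considered here, and "the series" means these few. Any claim that something is new, unique, unknown or untested is made for them only; others in the source may bear on it.

Measured compounds:
Compound 1, `CC1(/C=C/c2ccccc2)C=CC(=O)O1`: 119000 nM
Compound 2, `COc1ccc(/C=C/C2(C)C=CC(=O)O2)c(OC)c1`: 53600 nM

In a functional assay on HaCaT cells (Homo sapiens) for inhibition, read by sulforhodamine B assay, with a stated time of 48 h (a higher number here means a weaker inhibitor of growth, a lower number a stronger inhibitor of growth), compound 2 has the lowest of the two numbers. Its nearest neighbour is compound 1, whose number is higher than that of compound 2 by more than the usual scatter, so compound 2 is the stronger inhibitor of growth of the pair.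

Compound 3, `COc1ccc(/C=C/C2(C)C=CC(=O)O2)c(OC)c1OC`, has not yet been measured. It differs from compound 2 by methoxy in place of hydrogen on an aromatic carbon. Among the compounds with values here, no measured pair shows such a step. Because compound 2 sits at 53600 nM with two methoxy groups already in place, compound 3 is expected to move only slightly, if at all, in this assay, with the estimated step of a 1.3-fold lower number from compound 2 to compound 3 (0.13 log units; within the scatter) perhaps a small drop in the number. Compound 3 is estimated at 40000 nM, within 15000 nM to 100000 nM.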

Compound 3, concentration for total growth inhibition: 217000 nM
Beside the measured number, compound 3's estimate is 5.4-fold (0.73 log units) below it, and the stated range ends below it.
By their numbers in this assay, from the lowest: compound 2; then compounds 1 and 3 (each within the scatter of the next).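

In this assay, methoxy in place of hydrogen on this aromatic carbon, ortho to two methoxy groups, gives a 4.0-fold higher number from compound 2 to compound 3 (0.61 log units; beyond the scatter), so compound 3 is a weaker inhibitor of growth than compound 2. Within the data shown here, this is the first measured step at this position, and it shows that the change here is not neutral. Nothing measured here bears on the reason for the rise. Still open, from the compounds shown here alone, is how a hydroxyl, a fluorine or an amine on this same carbon would compare with hydrogen and methoxy.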